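The source may hold more compounds than are shown below. What is called first, only, known or untested is meant among the compounds shown, and "the series" means these compounds.

Measured in this assay:
compound 1 `CC1CCN(c2c(S(=O)(=O)c3ccc(F)c(F)c3)cnc3c(F)cccc23)CC1`: 93%
compound 2 `COc1ccc2ncc(S(=O)(=O)c3cccc(C#N)c3)c(N3CCC(C)CC3)c2c1`: 90%
compound 3 `Cc1cc(C)cc(S(=O)(=O)c2cnc3cc(F)ccc3c2N2CCC(C)CC2)c1`: 80%

In an assay on isolated protein for displacement of a labelled ligand from metabotropic glutamate receptor 5 (Homo sapiens), with a stated time of 60 min, tested at 1 uM (a higher number here means more inhibition at the concentration tested (going by the name of the read-out), a lower number less inhibition), compound 1 stands highest of the three numbers, though the gap to compound 2 lies within the scatter; only the gap to compound 3 lies beyond it. Compound 4 `CC1CCN(c2c(S(=O)(=O)c3ccccc3)cnc3c(F)cccc23)CC1` is not yet measured. It differs from compound 1 in one place: phenyl in place of 3,4-difluorophenyl on a sulfonyl sulfur. Going by the values given here, no step between two measured compounds isolates this change, so its size is unknown; at the tested concentration a number near the top of the scale leaves little room upward, and a small drop or none beyond the scatter is expected. For compound 4 the estimated step of a number 8 percentage points lower from compound 1 to compound 4 (within the scatter) gives 85% in this assay, within 70% to 97%.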

Compound 4, a percentage reported as inhibition, at one concentration (the size of the read-out at that concentration, not a potency): 13%
Compound 4: the middle estimate sits 72 percentage points above what was measured, outside the stated range (below it).
By their numbers in this assay, from the lowest: compound 4; then compounds 3, 2 and 1 (each within the scatter of the next, the first and the last beyond it).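

In this assay, phenyl in place of 3,4-difluorophenyl on a sulfonyl sulfur gives a number 80 percentage points lower from compound 1 to compound 4 (beyond the scatter). Going by these compounds alone, this is the only step that isolates one place, and it shows that, on the core of compound 1, the number depends heavily on the two fluorines of this aryl group. Nothing in the data at hand bears on the cause of this step.

Still open, on these data alone, is whether a monofluorophenyl group keeps part of the inhibition on this core. As far as these compounds go, a chlorophenyl or methoxyphenyl group at this place is equally open.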